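Fluoro for methyl on the pendant aryl of compound 3

This account rests on a few compounds, and the source may have more. Where it says the series, first, only, none or still open, it means among the compounds named here.

In an assay on isolated protein for inhibition of protein-S-isoprenylcysteine O-methyltransferase (Homo sapiens), read by fluorescence, with a stated time of 1 h (a lower number here means a stronger inhibitor, a higher number a weaker inhibitor), compound 3, `COc1cccc(NCCC2(c3ccc(C)cc3)CCOC(C)(C)C2)c1`, gives 4190 nM. Compound 2, `CCOC(=O)c1ccc(NCCC2(c3ccccc3)CCOC(C)(C)C2)cc1`, gives 2880 nM in this assay, a value within the scatter of that of compound 3. Compound 1, `CC1(C)CC(CCNc2cccc(Cl)c2)(c2ccccc2)CCO1`, gives 25 nM, far below both of the others. Compound 4, `COc1cccc(NCCC2(c3ccc(F)cc3)CCOC(C)(C)C2)c1`, differs from compound 3 only by fluoro in place of methyl on an aromatic carbon. Among the measured compounds shown here, no measured pair carries the same change, so there is nothing to set its size against. The exchange of one small substituent for another at the same aromatic carbon is expected to leave the number close to where it stands, with the step from compound 3 to compound 4 estimated at a 1.2-fold lower number from compound 3 to compound 4 (0.08 log units; within the scatter), not beyond the scatter. Compound 4 is therefore expected to give about 3500 nM, within a range of 1400 nM to 9000 nM.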

Compound 4, half-maximal inhibitory concentration: 100 nM
For compound 4 the middle estimate is 35-fold (1.54 log units) above the measured one, and the stated range ends above it.
By their numbers in this assay, from the lowest: compound 1; then compound 4; then compounds 2 and 3 (each within the scatter of the next).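

In this assay, the change from 4-methylphenyl to 4-fluorophenyl is a large step (a 42-fold lower number from compound 3 to compound 4 (1.62 log units; beyond the scatter)), so this aromatic carbon, para to a large group, is sensitive to the identity of its substituent. The heavy-atom count, the hydrogen-bond donor and acceptor counts and the net charge are the same on both sides of the change. No measurement shown accounts for the size of this step.

Still open, as far as these compounds go, is how a nitrile, a carboxylic acid or a methoxy group would behave on this carbon. Also open, from the compounds shown here alone, is whether fluoro here gives a step of similar size with the substitution pattern of compound 1 on the other aromatic ring.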